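This account rests on a few compounds, and the source may have more. Where it says the series, first, only, none or still open, it means among the compounds named here.

Measured in a functional assay for inhibition, with Rattus norvegicus as the target; on this read-out lower numbers stand for stronger inhibition and higher numbers for weaker inhibition:
- compound 1 `CC(/N=c1\c(O)c(O)\c1=N/c1cnc2ccccc2c1)C(C)(C)C`: > 30000 nM, a limit
- compound 2 `CC(/N=c1\c(O)c(O)\c1=N/c1ccc(OC(F)(F)F)cc1)C(C)(C)C`: > 30000 nM, a limit

Compound 2 yields no number, only the limit > 30000 nM. For the measured compounds named here, the series so far sits entirely at one boundary: the limit of > 30000 nM in this assay, at which 2 of the 2 values shown sit. Compound 3 `CC(/N=c1\c(O)c(O)\c1=N/c1ccc(C#N)cc1)C(C)(C)C` keeps the core of compound 2 and carries cyano in place of trifluoromethoxy on an aromatic carbon, para to a large group: cyano in place of trifluoromethoxy on an aromatic carbon.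

Going by the values given here, no measured step is available to size this change, so the expectation is weakly grounded. Compound 2 reads > 30000 nM, so a numeric result can only show stronger inhibition, although another limit remains quite possible. The estimate is an at least 10-fold lower number from compound 2 to compound 3 (1.00 log units; beyond the scatter), an expected move toward stronger inhibition in this assay. For compound 3 the expected value is 3000 nM, with an estimated range of 300 nM to 30000 nM.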

Compound 3, half-maximal inhibitory concentration: 520 nM
For compound 3 the middle estimate is 5.8-fold (0.76 log units) above the measured one; measured number inside the range.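

In this assay, the aromatic carbon para to a large group proves able to move the read-out: cyano in place of trifluoromethoxy gives an at least 57-fold lower number from compound 2 to compound 3 (1.76 log units; beyond the scatter), a step beyond the scatter and the first numeric result in the series. Compound 2 gives > 30000 nM, which is a limit, so this step marks only a lower bound on the true difference. The series no longer sits entirely at one boundary, though most of its values still do: the limit of > 30000 nM in this assay, at which 2 of the 3 values shown sit.

The compounds shown leave open whether the stronger inhibition is particular to cyano or would also appear with an amine, a carboxylic acid or a chlorine atom in the same place. With a single numeric value, they also leave open whether cyano would hold its effect if a shorter chain replaced the branched chain on the shared core.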